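Halogenated aryl ketones on a trimethoxyphenyl-pyrazole scaffold

The source may report more compounds than this note shows. Statements on the series, on what has been measured and on what is new or still open speak of the compounds shown alone.

The measured compounds:
compound 1, `COc1cc(-c2cc(/C=C/C(=O)c3ccc(Cl)c(Cl)c3)[nH]n2)cc(OC)c1OC`, 92%;
compound 2, `COc1ccc(C(=O)/C=C/c2cc(-c3cc(OC)c(OC)c(OC)c3)n[nH]2)cc1`, 87%;
compound 3, `COc1cc(C(=O)/C=C/c2cc(-c3cc(OC)c(OC)c(OC)c3)n[nH]2)cc(OC)c1OC`, 89%.

All three numbers come from a functional assay on SF-268 cells (Homo sapiens) for cytotoxicity, read by sulforhodamine B assay, with a stated time of 48 h, tested at 1 uM; a higher number here means a weaker effect of the compound at the concentration tested, a lower number a stronger effect. Compound 2 gives the lowest of the three readings, but its nearest neighbour, compound 3, sits only a couple of points higher and even compound 1 is within the usual scatter, so the three compounds cannot be told apart on these data.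

The new compound is compound 4, `COc1cc(-c2cc(/C=C/C(=O)c3ccc(F)c(F)c3)[nH]n2)cc(OC)c1OC`. Relative to compound 2 it carries one change: 3,4-difluorophenyl in place of 4-methoxyphenyl on a carbonyl carbon.

Going by the values given here, only one measured step bears on this change. Going from compound 1 to compound 2 replaced a 3,4-dichlorophenyl by a 4-methoxyphenyl on the carbonyl carbon and gave a number 5 percentage points lower from compound 1 to compound 2 (within the scatter), a shift that stays within the scatter. The move to compound 4 runs the other way, from a 4-methoxyphenyl to a dihalogenated phenyl, here the 3,4-difluorophenyl. By analogy the expected step of a number 3 percentage points higher from compound 2 to compound 4 (within the scatter) in this assay is no movement beyond the scatter.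

Compound 4 is therefore expected to give about 90%, with a range from 80% to 100%.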

Compound 4, a percentage reported as activity, at one concentration (the size of the read-out at that concentration, not a potency): 83%
For compound 4 the middle estimate is 7 percentage points above the measured one; the range from low to high includes it.
By their numbers in this assay, from the lowest: compounds 4, 2, 3 and 1 (each within the scatter of the next).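

With the 3,4-difluorophenyl on the carbonyl carbon, this position has now been read in this assay with a fluorinated aryl group as well as a chlorinated one and a methoxylated one, all on the same shared core. Replacing 4-methoxyphenyl with 3,4-difluorophenyl gives a step that is still small (a number 4 percentage points lower from compound 2 to compound 4 (within the scatter)), and the direct exchange of chlorine for fluorine on the same 3,4-disubstituted phenyl also stays inside the scatter (a number 9 percentage points lower from compound 1 to compound 4 (within the scatter)), so neither the kind of halogen nor the swap from halogens to a methoxy group separates these compounds at the single concentration tested. No measurement is available that bears on why these readings stay so close together.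

The compounds shown leave open whether any group on this carbonyl carbon can move the reading beyond the scatter, for instance a phenyl carrying a dimethylamino group or a carboxylic acid, or a longer chain in place of the aryl ring. They also leave open whether these close readings would still hold if the shared core were changed, since all of these compounds keep it.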